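A few compounds are considered here, and "the series" means these few. Any claim that something is new, unique, unknown or untested is made for them only; others in the source may bear on it.

Measured compounds:
Compound 1 `O=S(=O)(c1cc(F)cc(F)c1)c1cnc2cc(F)ccc2c1-c1ccc(Cl)cc1` – 0.03 mL/min
Compound 2 `COc1ccc(-c2c(S(=O)(=O)c3ccc(F)cc3)cnc3cc(F)ccc23)cc1` – 1.77 mL/min
Compound 3 `COc1ccc(-c2c(S(=O)(=O)c3ccc(F)c(F)c3)cnc3cc(F)ccc23)cc1` – 1.1 mL/min

In an ADME assay on microsomes from liver (Homo sapiens) for metabolic stability, tested at 2.5 uM (a lower number here means slower removal, a higher number faster removal of the compound), compound 3 stands second highest of the three numbers. Its nearest neighbour is compound 2, and the step of a 1.6-fold lower number from compound 2 to compound 3 (0.21 log units; within the scatter) lies within the scatter. Going by the values given here, its furthest neighbour is compound 1, whose value is far lower and beyond the scatter; no single-change step links those two compounds.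

Compound 4 `COc1ccc(-c2c(S(=O)(=O)c3cc(F)cc(F)c3)cnc3cc(F)ccc23)cc1` differs from compound 3 in one place: 3,5-difluorophenyl in place of 3,4-difluorophenyl on a sulfonyl sulfur. Among the compounds with values here, the only measured step that touches the same sulfonyl substituent, the step from compound 2 to compound 3, was within the scatter. Compound 1 also carries a 3,5-difluorophenyl but differs from compound 4 elsewhere as well, so its low value cannot be assigned to that group alone. A step of a 1.6-fold lower number from compound 3 to compound 4 (0.20 log units; within the scatter) of modest size is therefore expected, and compound 4 is estimated at 0.7 mL/min, with a range from 0.25 mL/min to 2 mL/min.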

Compound 4, intrinsic clearance in a liver preparation (reported as CLH), per the amount of preparation that the assay uses: 1.51 mL/min
Compound 4: middle estimate off by 2.2-fold (0.33 log units), on the low side; the measured number falls inside the stated range.
By their numbers in this assay, from the lowest: compound 1; then compounds 3, 4 and 2 (each within the scatter of the next).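

In this assay, 3,5-difluorophenyl on the sulfonyl sulfur gives a 1.4-fold higher number from compound 3 to compound 4 (0.14 log units; within the scatter) and a 1.2-fold lower number from compound 2 to compound 4 (0.07 log units; within the scatter), so the three aryl groups at this place are not told apart. With 3,5-difluorophenyl held constant, methoxy in place of chloro on an aromatic carbon gives a 50-fold higher number from compound 1 to compound 4 (1.70 log units; beyond the scatter), placing the large gap at that change rather than at the sulfonyl substituent. No available evidence bears on the reason for this gap.

On these data alone, it remains open whether the step holds with the other two sulfonyl substituents. Where a nitrile or an amine in that place would fall also remains open.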